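The source may hold more compounds than are shown below. What is called first, only, known or untested is meant among the compounds shown, and "the series" means these compounds.

In a functional assay on PC-3 cells (Homo sapiens) for cytotoxicity, read by MTT assay, with a stated time of 72 h (a lower number here means a stronger inhibitor, a higher number a weaker inhibitor), compound 1 `O=C(/C=C/c1ccccc1)NNC(=O)c1ccccc1O` gives 40900 nM. Compound 2 `COCOc1cc(/C=C/C(=O)OCC(=O)Nc2ccc(Cl)cc2)ccc1OCc1ccccc1` reads > 200000 nM, which is a limit. Compound 3 `COCOc1cc(/C=C/C(=O)OCC(=O)NN2CCOCC2)ccc1OCc1ccccc1` reads > 200000 nM, also a limit, so it has no number of its own. Compound 3 therefore stands at the limit of > 200000 nM in this assay, at which 2 of the 3 values shown sit. Compound 4 `COCOc1cc(/C=C/C(=O)OCC(=O)NCc2ccco2)ccc1OCc1ccccc1` carries one change from compound 3: (furan-2-yl)methyl in place of morpholin-4-yl on an amide-type nitrogen, with (furan-2-yl)methyl in place of morpholin-4-yl on an amide-type nitrogen. For the measured compounds named here, the only measured step at that nitrogen is a step that the two limits leave unreadable from compound 2 to compound 3, so it offers no size or direction to carry over. No shift beyond the scatter is expected, and the expected step is a number no higher from compound 3 to compound 4 (the limit leaves the size open). A further reading at the limit is the likeliest outcome. For compound 4 the estimate is 200000 nM, with an expected range of 80000 nM to 300000 nM.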

Compound 4, half-maximal inhibitory concentration: > 200000 nM
Compound 4: no number, only a limit; the forecaster's own chance of this, stated with the estimate: 70%; the middle value sits exactly at the limit.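

No new step can be read: compound 2, compound 3 and compound 4 each give only a limit in this assay. The compounds shown leave open how the three groups on the amide-type nitrogen compare.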